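Acetamido for hydroxy on the sulfonyl of compound 3

The source may report more compounds than this note shows. Statements on the series, on what has been measured and on what is new or still open speak of the compounds shown alone.

Measured so far:
Compound 1, `O=S(=O)(O)O[C@@H]1[C@H](O)C[C@@H](O)C[C@H]1OCCCCc1ccccc1O` — 90000 nM
Compound 2, `CC(=O)NS(=O)(=O)O[C@@H]1[C@H](O)C[C@@H](O)C[C@H]1OCCCCc1ccccc1O` — a limit of the assay, > 300000 nM
Compound 3, `O=C1CCCCC1CCCCO[C@@H]1C[C@H](O)C[C@@H](O)[C@H]1OS(=O)(=O)O` — 100000 nM

In an assay on isolated protein for inhibition of inositol monophosphatase 1 (Bos taurus) (on this read-out lower numbers stand for stronger inhibition and higher numbers for weaker inhibition), compound 3 gives 100000 nM, the higher of the two numbers shown, although the only gap shown is small: a 1.1-fold higher number from compound 1 to compound 3 (0.05 log units; within the scatter). Compound 4, `CC(=O)NS(=O)(=O)O[C@@H]1[C@H](O)C[C@@H](O)C[C@H]1OCCCCC1CCCCC1=O`, has not been measured; it differs from compound 3 by acetamido in place of hydroxy on a sulfonyl sulfur. The same exchange has been seen once, as an at least 3.3-fold higher number from compound 1 to compound 2 (0.52 log units; beyond the scatter), where the value of compound 2 sits at the limit of > 300000 nM in this assay, at which 1 of the 3 values shown sits. A step of at least modest size toward weaker inhibition is therefore expected for compound 4, namely a 3.5-fold higher number from compound 3 to compound 4 (0.54 log units; beyond the scatter). The estimate for compound 4 is 350000 nM, with a range from 150000 nM to 1000000 nM, and a limit rather than a number is the likelier outcome.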

Compound 4, half-maximal inhibitory concentration: > 300000 nM
Compound 4 was reported as a limit (the forecaster's own chance of this, stated with the estimate: 60%); the middle value lies beyond the limit too.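

In this assay acetamido in place of hydroxy on the sulfonyl sulfur gives an at least 3.0-fold higher number from compound 3 to compound 4 (0.47 log units; beyond the scatter), so the move toward weaker inhibition seen with the 2-hydroxyphenyl chain also appears with the 2-oxocyclohexyl chain. The change now has the same direction on two cores, with compound 2 and compound 4 both reported as limits: the same change on two cores in this assay, an at least 3.3-fold higher number (0.52 log units; beyond the scatter) from compound 1 to compound 2 and an at least 3.0-fold higher number (0.47 log units; beyond the scatter) from compound 3 to compound 4; the limit leaves it open whether they differ. The step from compound 2 to compound 4 cannot be read.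

From the compounds shown here alone, it remains open whether a plain amino group on the sulfonyl sulfur, without the acetyl, would keep the inhibition of compound 3. Going by these compounds, the effect of a longer chain also remains open.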